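The compounds below may be only part of what the source reports. "The series", "measured", "known", "first", "only" and "open" are said of these compounds alone.

Measured compounds:

Compound 1, `Cc1cc(NS(=O)(=O)c2ccc(N/C=C\C(=O)c3cc4ccccc4oc3=O)cc2)on1` — 75600 nM
Compound 2, `Cc1noc(NS(=O)(=O)c2ccc(N/C=C\C(=O)c3cc4ccccc4oc3=O)cc2)c1C` — 68400 nM
Compound 3, `O=C(/C=C\Nc1ccc(S(=O)(=O)Nc2ncccn2)cc1)c1cc2ccccc2oc1=O` — 75200 nM

All three were tested in a functional assay on T47D cells (Homo sapiens) for cytotoxicity, read by sulforhodamine B assay, with a stated time of 48 h; on this read-out higher numbers stand for weaker inhibition and lower numbers for stronger inhibition. Compound 1 and compound 2 differ by methyl in place of hydrogen on an aromatic carbon, and that change gave a 1.1-fold lower number from compound 1 to compound 2 (0.04 log units; within the scatter). Compound 1 and compound 3 differ in their cores by pyrimidin-2-yl in place of 3-methyl-1,2-oxazol-5-yl on a sulfonamide nitrogen, with a 1.0-fold lower number from compound 1 to compound 3 (0.00 log units; within the scatter). Comparing compound 2 with compound 3, a 1.1-fold higher number from compound 2 to compound 3 (0.04 log units; within the scatter). None of these three numbers can be told apart from one another.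

Compound 4, `Cc1ccnc(NS(=O)(=O)c2ccc(N/C=C\C(=O)c3cc4ccccc4oc3=O)cc2)n1`, has not yet been measured. It differs from compound 3 by methyl in place of hydrogen on an aromatic carbon. For the measured compounds named here, this is the same kind of change as the one from compound 1 to compound 2, but the surroundings are not the same: in compound 2 the methyl sits on an aromatic carbon of a five-membered aromatic ring with 1 nitrogen and 1 oxygen, next to the ring atom that bears a large group and two ring bonds from the ring nitrogen and the ring oxygen, whereas in compound 4 it sits on an aromatic carbon of a six-membered aromatic ring with 2 nitrogen, next to the ring nitrogen and opposite the ring nitrogen.

Given that the earlier methyl step gave a 1.1-fold lower number from compound 1 to compound 2 (0.04 log units; within the scatter) and that the core change gave a 1.0-fold lower number from compound 1 to compound 3 (0.00 log units; within the scatter), the step from compound 3 to compound 4 is expected to be a 1.0-fold lower number from compound 3 to compound 4 (0.02 log units; within the scatter). Compound 4 is therefore estimated at 72000 nM, expected to lie somewhere from 40000 nM to 130000 nM.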

Compound 4, half-maximal inhibitory concentration: 24500 nM
The estimate for compound 4 lay 2.9-fold (0.47 log units) above the measured number, outside the stated range (below it).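

In this assay, methyl in place of hydrogen on an aromatic carbon of the six-membered aromatic ring gave a 3.1-fold lower number from compound 3 to compound 4 (0.49 log units; beyond the scatter), and compound 4 also separates from the two compounds that carry a five-membered ring, with a 2.8-fold lower number from compound 2 to compound 4 (0.45 log units; beyond the scatter) and a 3.1-fold lower number from compound 1 to compound 4 (0.49 log units; beyond the scatter). The methyl change therefore did not carry over from one core to the other with the same size: the same change on two cores in this assay, a 1.1-fold lower number (0.04 log units; within the scatter) from compound 1 to compound 2 and a 3.1-fold lower number (0.49 log units; beyond the scatter) from compound 3 to compound 4, 2.8-fold (0.44 log units) apart, beyond the scatter of two such steps. This shows that the step seen on one core in this series cannot simply be transferred to another, but it rests on a single pair for each core, and the two methyl groups also sit in different surroundings, so it does not show which difference between the pairs sets the size of the step, nor how the change would behave on any further core.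

The compounds shown leave open whether ethyl, methoxy or chlorine in place of the methyl of the 4-methylpyrimidin-2-yl group would give a step of similar size. They also leave open what an amine or a carboxylic acid on that same aromatic carbon would do in this assay.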